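A few compounds are considered here, and "the series" means these few. Any claim that something is new, unique, unknown or untested is made for them only; others in the source may bear on it.

Measured so far in an assay on HeLa cells for inhibition of Indoleamine 2,3-dioxygenase 1 (Homo sapiens), read by spectrophotometry, with a stated time of 24 h; on this read-out higher numbers stand for an effect only at larger amounts of compound and lower numbers for an effect already at smaller amounts:
compound 1, `NNc1nonc1/C(=N/O)Nc1ccc(F)c(Br)c1`, 556 nM;
compound 2, `N=S1(=O)CC(Nc2nonc2/C(=N/O)Nc2ccc(F)c(Br)c2)C1`, 53 nM;
compound 3, `O=S(=O)(CCNc1nonc1/C(=N/O)Nc1ccc(F)c(Br)c1)N1CCC1`, 143 nM.

Compound 3 stands second highest of these three numbers: compound 2 sits closest, with a 2.7-fold higher number from compound 2 to compound 3 (0.43 log units; beyond the scatter), and compound 1 farthest, with a 3.9-fold lower number from compound 1 to compound 3 (0.59 log units; beyond the scatter). The step to compound 4, `NNS(=O)(=O)CCNc1nonc1/C(=N/O)Nc1ccc(F)c(Br)c1`, is aminoamino in place of azetidin-1-yl on a sulfonyl sulfur. No measured step changes the group on the sulfonyl sulfur, so the three steps shown, all replacing the whole substituent on the ring nitrogen, bear on it only loosely. They do show that every substituent tried there gives a lower number than compound 1, and that compound 2 gives the lowest. The expected step is therefore small, a 1.2-fold lower number from compound 3 to compound 4 (0.08 log units; within the scatter), in this assay, within the scatter. Compound 4 is estimated at 120 nM, between 45 nM and 320 nM.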

Compound 4, half-maximal effective concentration: > 800 nM
Compound 4 ended at the assay's limit; the forecaster's own chance of this, stated with the estimate: 3%; middle value at least 6.6-fold (0.82 log units) from the limit.
By their numbers in this assay, from the lowest: compound 2; then compound 3; then compound 1. At a limit, above all of these: compound 4.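

In this assay, the group on the sulfonyl sulfur turns out to matter: aminoamino in place of azetidin-1-yl gives an at least 5.5-fold higher number from compound 3 to compound 4 (0.74 log units; beyond the scatter). Earlier, every substituent on the ring nitrogen had lowered the number; here the result is an at least 1.4-fold higher number from compound 1 to compound 4 (0.15 log units; that floor lies within the scatter). The lowest of them stays well apart, with an at least 15-fold higher number from compound 2 to compound 4 (1.17 log units; beyond the scatter). Compound 4 stands at a limit of the assay: the limit of > 800 nM in this assay, at which 1 of the 4 values shown sits.

As far as these compounds go, how a pyrrolidin-1-yl or dimethylamino group on the sulfonyl sulfur would read remains open. So does whether the rise belongs to losing the ring or to the entering aminoamino.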